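This account rests on a few compounds, and the source may have more. Where it says the series, first, only, none or still open, it means among the compounds named here.

In a functional assay on U-937 cells (Homo sapiens) for cytotoxicity, read by MTT assay, with a stated time of 48 h (on this read-out lower numbers stand for stronger inhibition and higher numbers for weaker inhibition), three compounds that share one core have been measured. Compound 1, with structure `S=C(Nc1ccc(Cl)cc1)Nc1nc2ccccc2s1`, carries a thiourea link to a chloro-substituted benzene ring. For compound 1 the assay gives only a limit, > 50000 nM, rather than a number, as noted in the limit of > 50000 nM in this assay, at which 1 of the 3 values shown sits. Compound 3, `Fc1ccc(NC(=S)Nc2nc3ccccc3s2)cc1`, keeps that thiourea but carries fluoro instead of chloro, and compound 3 gives 32100 nM. The step of an at least 1.5-fold lower number from compound 1 to compound 3 (0.19 log units; that floor lies within the scatter) therefore rests on a limit at one end. Compound 2, `Cc1ccc2nc(Nc3nc4ccccc4s3)sc2c1`, differs in kind: the thiourea link is gone and the second ring system is joined directly to the core. In this assay compound 2 gives 48400 nM, which lies within the scatter of the value of compound 3, so the two cannot be placed in any order.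

Compound 4, `Cc1ccc2nc(Nc3nc4ccc(F)cc4s3)sc2c1`, is built from compound 2 by fluoro in place of hydrogen on an aromatic carbon. No measured step touches this ring, and the only halogen step shown, from compound 1 to compound 3, has a floor that lies within the scatter. For this assay the step of a 1.2-fold lower number from compound 2 to compound 4 (0.08 log units; within the scatter) is expected to stay within the scatter, and compound 4 is estimated at 40000 nM, between 15000 nM and 100000 nM.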

Compound 4, half-maximal inhibitory concentration: > 50000 nM
Compound 4: only a limit was reported (the forecaster's own chance of this, stated with the estimate: 35%); middle value at least 1.2-fold (0.09 log units) from the limit.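

In this assay compound 4 gives only a limit, > 50000 nM, and it is the first compound shown with a change on this six-membered aromatic ring of the shared core, so this position can now be judged for the first time. Fluoro in place of hydrogen here gives an at least 1.0-fold higher number from compound 2 to compound 4 (0.01 log units; that floor lies within the scatter), which means the step has only a floor, its true size cannot be read, and this one small change shows no lower number in this read-out. The earlier halogen step, from chloro to fluoro, concerned the ring on the thiourea side, whereas this result concerns the core itself, and it adds a second compound to those that give no exact number: the limit of > 50000 nM in this assay, at which 2 of the 4 values shown sit.

Fluoro is the only group shown at this position, so it remains open whether a larger or different group, such as an amine, a methoxy group or a carboxylic acid, would bring a clearly lower number here. On these data alone, it is also open whether the same fluoro on the core would behave alike in a compound that keeps the thiourea link, such as compound 3.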